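Swapping a sulfonamide chain for an aryl ether chain

This account rests on a few compounds, and the source may have more. Where it says the series, first, only, none or still open, it means among the compounds named here.

Of the compounds shown here, two from this study have been tested in a functional assay on PANC-1 cells (Homo sapiens) for inhibition, read by MTT assay, with a stated time of 24 h, tested at 10 uM (a lower number here means less inhibition, a higher number more inhibition at the concentration tested (going by the name of the read-out)), so far. Compound 1 `CC(C)=CCC1Cc2c(OCc3ccccc3)cc(=O)n(CCCO)c2CC1(C)C` carries a benzyloxy group on the shared core and gives -0.3% in this assay. Compound 2 `CC(C)=CCC1Cc2c(OCCCNS(=O)(=O)c3ccc(Br)cc3)cc(=O)n(CCCO)c2CC1(C)C` instead carries a longer chain ending in a bromophenyl sulfonamide, and in this assay compound 2 gives 19.5%. Compound 2 therefore stands highest of the two numbers, and its gap to compound 1 is larger than the usual scatter of repeated measurements.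

Compound 3 `COc1ccc(OCCCOc2cc(=O)n(CCCO)c3c2CC(CC=C(C)C)C(C)(C)C3)cc1` has not yet been measured. It differs from compound 2 in one place: 4-methoxyphenoxy in place of ((4-bromophenyl)sulfonyl)amino on a saturated chain carbon, three bonds along the chain from an oxygen on an aromatic ring. For the measured compounds named here, no step between measured compounds shows what such a change does, so the expectation for compound 3 rests only on the two numbers available. Because compound 2 gives 19.5% with the sulfonamide chain, while compound 1 without any such chain gives -0.3%, compound 3 is expected to sit between the two, and the step of a number 11.5 percentage points lower from compound 2 to compound 3 (beyond the scatter) is expected to be a modest decrease that may not exceed the scatter. For compound 3 the estimate in this assay is 8%, within a range from -8% to 28%.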

Compound 3, a percentage reported as inhibition, at one concentration (the size of the read-out at that concentration, not a potency): 47.7%
Estimate against measurement, compound 3: 39.7 percentage points below; the measured number lies above the stated range.
By their numbers in this assay, from the lowest: compound 1; then compound 2; then compound 3.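

In this assay, 4-methoxyphenoxy in place of ((4-bromophenyl)sulfonyl)amino gives a number 28.2 percentage points higher from compound 2 to compound 3 (beyond the scatter), so the group at the end of this chain clearly changes the read-out, not merely the chain's presence. The entering group has no hydrogen-bond donor, while the leaving group has one, so a donor at this place is not required for inhibition at the concentration tested. Against the simple benzyloxy compound, 2-(4-methoxyphenoxy)ethyl in place of phenyl on a saturated chain carbon bound to an oxygen on an aromatic ring gives a number 48 percentage points higher from compound 1 to compound 3 (beyond the scatter), showing that this side of the shared core can carry a much larger group and still yield a higher number.

Nothing measured here explains the rise. The exchange alters the linking atoms, the ring substituent and the donor count together, so a 4-bromophenoxy group, a 4-methoxyphenyl sulfonamide, or a terminal amine on the same chain would be needed to separate those parts, and a longer or shorter chain would test whether the chain length matters.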